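A few compounds are considered here, and "the series" means these few. Any claim that something is new, unique, unknown or untested is made for them only; others in the source may bear on it.

Of the compounds shown here, three built on one shared core have been tested in a functional assay on C6 cells (Rattus norvegicus) for cytotoxicity, read by MTT assay, with a stated time of 24 h; on this read-out higher numbers stand for weaker inhibition and lower numbers for stronger inhibition. Compound 1 `Cc1cc(-c2nc3ccccc3o2)ccc1NC(=O)CN1CCN(CCN(C)C)CC1` gives 42700 nM. Compound 2 `Cc1cc(-c2nc3ccccc3o2)ccc1NC(=O)CN1CCN(CCCN(C)C)CC1` gives 38700 nM. Compound 3 `Cc1cc(-c2nc3cc(F)ccc3o2)ccc1NC(=O)CN1CCN(CCCN(C)C)CC1` gives 11800 nM, the lowest of the three, and its steps to both other compounds are beyond the scatter.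

Compounds 2 and 1 differ in one place: dimethylamino in place of (dimethylamino)methyl on a saturated chain carbon, two bonds along the chain from an amine nitrogen in a ring. That change made a 1.1-fold higher number from compound 2 to compound 1 (0.04 log units; within the scatter), so the two compounds cannot be told apart by this read-out.

Compounds 2 and 3 differ elsewhere: fluoro in place of hydrogen on an aromatic carbon. That change made a 3.3-fold lower number from compound 2 to compound 3 (0.52 log units; beyond the scatter), a modest but real step toward stronger inhibition.

Compound 4 `Cc1cc(-c2nc3cc(F)ccc3o2)ccc1NC(=O)CN1CCN(CCN(C)C)CC1` has not yet been measured in this assay. It differs from compound 3 by dimethylamino in place of (dimethylamino)methyl on a saturated chain carbon, two bonds along the chain from an amine nitrogen in a ring. For the measured compounds named here, this is the same kind of change as the one from compound 2 to compound 1, made on the core that carries the fluoro group instead. Because the earlier change gave a 1.1-fold higher number from compound 2 to compound 1 (0.04 log units; within the scatter), the expectation is that this assay will again show little movement, and the step from compound 3 to compound 4 is estimated at a 1.1-fold higher number from compound 3 to compound 4 (0.04 log units; within the scatter). That expectation rests on a single earlier pair, so it is held loosely. Compound 4 is expected to give about 13000 nM in this assay, most likely between 6000 nM and 28000 nM.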

Compound 4, half-maximal inhibitory concentration: 10700 nM
The estimate for compound 4 lay 1.2-fold (0.08 log units) above the measured number; the measured number falls inside the stated range.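

On the core that carries the fluoro group, replacing the 3-(dimethylamino)propyl chain with the 2-(dimethylamino)ethyl chain gave a 1.1-fold lower number from compound 3 to compound 4 (0.04 log units; within the scatter) in this assay, and this chain change behaved alike on both cores: the same change on two cores in this assay, a 1.1-fold higher number (0.04 log units; within the scatter) from compound 2 to compound 1 and a 1.1-fold lower number (0.04 log units; within the scatter) from compound 3 to compound 4, 1.2-fold (0.09 log units) apart, within the scatter of two such steps. The fluoro change also carried over, giving a 4.0-fold lower number from compound 1 to compound 4 (0.60 log units; beyond the scatter) on the 2-(dimethylamino)ethyl chain, much like its step on the 3-(dimethylamino)propyl chain: the same change on two cores in this assay, a 3.3-fold lower number (0.52 log units; beyond the scatter) from compound 2 to compound 3 and a 4.0-fold lower number (0.60 log units; beyond the scatter) from compound 1 to compound 4, 1.2-fold (0.09 log units) apart, within the scatter of two such steps. Across these four compounds, each change therefore moved the number by about the same amount whichever form the other part took, but this rests on a single comparison per change, in one cell assay, and it does not explain why the fluoro group lowers the number or show that either result would hold on a different core.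

The compounds shown leave open whether a longer chain, or a ring amine such as pyrrolidine or morpholine in place of the dimethylamino group, would also leave the number within the scatter. They also leave open whether chloro or methoxy in place of the fluoro group would give a step of similar size.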